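Swapping the aryl amide in a nitrile-bearing bis-indole scaffold

The source may hold more compounds than are shown below. What is called first, only, known or untested is meant among the compounds shown, and "the series" means these compounds.

Three compounds share the same core and differ only in the group attached through a chain to one of the saturated ring carbons. Compound 1 `CN1[C@@H]2c3[nH]c4ccccc4c3C[C@H]1[C@H](C#N)N1[C@@H](CN3C(=O)c4ccccc4C3=O)c3[nH]c4ccccc4c3C[C@@H]21` carries a phthalimide-type ring there and in a functional assay on A2780 cells (Homo sapiens) for cytotoxicity, read by MTT assay, with a stated time of 72 h (a lower number here means a stronger inhibitor, a higher number a weaker inhibitor), compound 1 gives 80 nM. Compound 2 `CN1[C@@H]2c3[nH]c4ccccc4c3C[C@H]1[C@H](C#N)N1[C@@H](CNC(=O)c3ccc(Cl)cc3)c3[nH]c4ccccc4c3C[C@@H]21` instead carries a (4-chlorophenyl)carbonyl amino group, and in this assay compound 2 gives 230 nM, the highest of the three numbers; the step of a 2.9-fold higher number from compound 1 to compound 2 (0.46 log units; beyond the scatter) is beyond the scatter. Compound 3 `CN1[C@@H]2c3[nH]c4ccccc4c3C[C@H]1[C@H](C#N)N1[C@@H](CNC(=O)c3ccc4ccccc4n3)c3[nH]c4ccccc4c3C[C@@H]21` replaces the 4-chlorophenyl by quinolin-2-yl, and in this assay compound 3 gives 60 nM, so the step of a 3.8-fold lower number from compound 2 to compound 3 (0.58 log units; beyond the scatter).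

Compound 4 `CN1[C@@H]2c3[nH]c4ccccc4c3C[C@H]1[C@H](C#N)N1[C@@H](CNC(=O)c3cc4ccccc4s3)c3[nH]c4ccccc4c3C[C@@H]21` has not yet been measured. It differs from compound 2 by 1-benzothiophen-2-yl in place of 4-chlorophenyl on a carbonyl carbon. For the measured compounds named here, the only directly comparable measured step is that from compound 2 to compound 3, where a second aromatic ring joined to the carbonyl replaced the same 4-chlorophenyl and the number fell modestly. Since the change to compound 4 also brings a two-ring aromatic group with one hydrogen-bond acceptor onto that carbonyl, a modest fall in this assay is expected for compound 4, estimated as a 2.6-fold lower number from compound 2 to compound 4 (0.41 log units; beyond the scatter). The expected value for compound 4 is 90 nM, with a range from 35 nM to 250 nM.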

Compound 4, half-maximal inhibitory concentration: 20 nM
Estimate against measurement, compound 4: 4.5-fold (0.65 log units) above; measured number outside the range, below it.
By their numbers in this assay, from the lowest: compound 4; then compounds 3 and 1 (each within the scatter of the next); then compound 2.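

Putting 1-benzothiophen-2-yl on this carbonyl gives the largest step seen at this position in this assay (a 12-fold lower number from compound 2 to compound 4 (1.06 log units; beyond the scatter)), and it also goes clearly beyond the other replacement for 4-chlorophenyl, quinolin-2-yl (a 3.0-fold lower number from compound 3 to compound 4 (0.48 log units; beyond the scatter)), so the identity of the aromatic group still matters once a group with two rings is in place. The same change also goes beyond the phthalimide-type group of compound 1 (a 4.0-fold lower number from compound 1 to compound 4 (0.60 log units; beyond the scatter)), which makes compound 4 the strongest of the four, with each of its steps to the other three printed as beyond the scatter. Nothing measured here accounts for these differences between the groups on the carbonyl.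

The compounds shown leave open whether the sulfur atom of the 1-benzothiophen-2-yl group is needed, a question that a 1-benzofuran-2-yl group, with oxygen in place of sulfur, would help to answer. They also leave open what the amide hydrogen contributes, which a methyl group on the amide nitrogen would test with the 1-benzothiophen-2-yl group kept in place.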